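Three Ureas at the Cytotoxicity Limit, a Fourth Expected Alike

A few compounds are considered here, and "the series" means these few. Any claim that something is new, unique, unknown or untested is made for them only; others in the source may bear on it.

Compound 1 `COc1ccc(NC(=O)Nc2cc(C)nc3ccccc23)cc1F`, measured in an ADME assay on HepG2 cells (Homo sapiens) for cytotoxicity, with a stated time of 72 h (a lower number here means that less compound is needed, a higher number that more compound is needed for the effect), gives only the limit > 25000 nM.
Compound 2 `Cc1cc(NC(=O)Nc2cc(F)ccc2F)c2ccccc2n1` likewise gives only the limit > 25000 nM.
Compound 3 `Cc1cc(NC(=O)Nc2ncccc2C)c2ccccc2n1` gives only the limit > 25000 nM.

Compound 3 thus stands at the limit of this assay, a position it shares with the other two, because of the limit of > 25000 nM in this assay, at which 3 of the 3 values shown sit. Among the measured compounds shown here, no step between measured compounds is available here, so nothing shows how a change on the amide-type nitrogen moves this read-out.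

Compound 4 `Cc1cc(NC(=O)Nc2ccc(F)cc2)c2ccccc2n1` differs from compound 3 by 4-fluorophenyl in place of 3-methylpyridin-2-yl on an amide-type nitrogen. Since all measured compounds sit at the limit, no step beyond the usual scatter is expected: a step that the limit leaves unreadable from compound 3 to compound 4 is the estimated change. Compound 4 is expected to give about 30000 nM, within 15000 nM to 60000 nM, most likely again reported only as a limit.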

Compound 4, half-maximal effective concentration: > 25000 nM
Compound 4: no number, only a limit; the forecaster's own chance of this, stated with the estimate: 85%; the middle value does not contradict the limit.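

In this assay, among the compounds shown here, compound 3 and compound 4 both give only a limit, and no step between them can be read. The compounds shown leave open what concentration of any of these four ureas would reach the half-maximal effect.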